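Trading a Methyl for a Hydroxy on the Tert-Butyl

The source may hold more compounds than are shown below. What is called first, only, known or untested is meant among the compounds shown, and "the series" means these compounds.

For the measured compounds named here, in a functional assay on PC-3 cells (Homo sapiens) for inhibition, read by MTT assay, with a stated time of 72 h (on this read-out lower numbers stand for stronger inhibition and higher numbers for weaker inhibition), compound 1 `CC(C)c1ccc(Nc2ccc(C(=O)C(Cl)Cl)cc2[N+](=O)[O-])cc1` gives 380 nM and compound 2 `CC(C)(C)c1ccc(Nc2ccc(C(=O)C(Cl)Cl)cc2[N+](=O)[O-])cc1` gives 470 nM, so compound 2 stands level with its only neighbour. Compound 3 `CC(C)(O)c1ccc(Nc2ccc(C(=O)C(Cl)Cl)cc2[N+](=O)[O-])cc1` differs from compound 2 by hydroxy in place of methyl on a saturated chain carbon bound to an aromatic carbon and two saturated chain carbons. Going by the values given here, the one measured step at this carbon, a 1.2-fold higher number from compound 1 to compound 2 (0.09 log units; within the scatter), swapped hydrogen for methyl, so it offers only a loose guide to a hydroxy. In this assay, a moderate weakening is expected, a 2.3-fold higher number from compound 2 to compound 3 (0.37 log units; beyond the scatter). Compound 3 is estimated at 1100 nM, within a range of 400 nM to 3500 nM.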

Compound 3, half-maximal inhibitory concentration: 2340 nM
For compound 3 the middle estimate is 2.1-fold (0.33 log units) below the measured one; low and high end bracket the measured number.
By their numbers in this assay, from the lowest: compounds 1 and 2 (each within the scatter of the next); then compound 3.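

In this assay this carbon proves far less forgiving than the first pair suggested: going from hydrogen to methyl moved the number only within the scatter, whereas hydroxy in place of methyl gives a 5.0-fold higher number from compound 2 to compound 3 (0.70 log units; beyond the scatter) and hydroxy in place of hydrogen gives a 6.2-fold higher number from compound 1 to compound 3 (0.79 log units; beyond the scatter). So among these three compounds, the identity of the group matters here more than its size alone. No measurement shown explains this loss. As far as these compounds go, whether a methoxy, an amine or a carboxylic acid at this carbon would track with hydroxy or with methyl remains open.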